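A few compounds are considered here, and "the series" means these few. Any claim that something is new, unique, unknown or untested is made for them only; others in the source may bear on it.

Compound 1 `Fc1ccc2nc(-c3ccccc3)nc(Nc3ccccc3)c2c1` gives > 50000 nM in a functional assay on HT29-AK cells (Homo sapiens) for cytotoxicity, read by MTT assay, with a stated time of 48 h (a higher number here means a weaker inhibitor, a lower number a stronger inhibitor), which is a limit of the assay and not a number. Compound 2 `Fc1ccc(Nc2nc(-c3cccc(F)c3)nc3ccc(F)cc23)cc1` gives > 50000 nM, likewise a limit. Compound 3 `Fc1cccc(-c2nc(Nc3ccccc3F)c3cc(F)ccc3n2)c1` gives > 50000 nM, again only a limit.

Within the data shown here, compound 3 therefore stands where every measured value so far stands, at the limit of > 50000 nM in this assay, at which 3 of the 3 values shown sit. Among the measured compounds shown here, the single step between measured compounds that differ in one place, a step that the two limits leave unreadable from compound 2 to compound 3, cannot be sized, since both of its ends are limits. Compound 4 `Fc1cccc(-c2nc(Nc3ccccc3Br)c3cc(F)ccc3n2)c1` differs from compound 3 by bromo in place of fluoro on an aromatic carbon. For the measured compounds named here, no measured step bears on this exchange, and the one step that is recorded gives no reading at all, so the expectation can rest only on where compound 3 stands and on the fact that all three values so far are limits. Compound 4 is expected to give about 50000 nM, in a range from 20000 nM to 150000 nM, and most probably to be reported as a limit once more. The step this estimate implies, a number no higher from compound 3 to compound 4 (the limit leaves the size open), is expected to lie within the scatter.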

Compound 4, half-maximal inhibitory concentration: > 50000 nM
Compound 4: a limit, no number (the forecaster's own chance of this, stated with the estimate: 85%); the middle value lies on the limit itself.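

Compound 4 gives > 50000 nM in this assay, again a limit and not a number, so its steps from compound 2 and compound 3 cannot be read. The compounds shown leave open whether bromo and fluoro differ here, and what any true value would be: the limit of > 50000 nM in this assay, at which 4 of the 4 values shown sit.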